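The compounds below may be only part of what the source reports. "The series", "measured", "known", "first", "only" and "open" are said of these compounds alone.

Working notes on the series. In a functional assay on HCT-116 cells (Homo sapiens) for cytotoxicity, read by MTT assay, with a stated time of 72 h (a lower number here means a stronger inhibitor, a higher number a weaker inhibitor), compound 1 `Nc1ccccc1NC(=O)c1ccc(NC(=S)NCc2ccc(Cl)nc2)cc1` gives 6100 nM. Compound 2 `Nc1ccccc1NC(=O)c1ccc(CNC(=O)c2cc3cnccc3[nH]2)cc1` gives 4000 nM. Going by the values given here, these two values lie within the usual scatter of each other, so compound 1 stands level with the only other number available. Among the compounds with values here, the two compounds differ in more than one place, and no step between measured compounds isolates a single structural change.

Compound 3 `Nc1ccccc1NC(=O)c1ccc(NC(=S)NCc2cccnc2)cc1` has not yet been measured. Its difference from compound 1 is hydrogen in place of chloro on an aromatic carbon, so that 6-chloropyridin-3-yl becomes pyridin-3-yl. Within the data shown here, the data contain no measured example of this change and so favour neither direction. The expectation in this assay is therefore no step beyond the scatter, with compound 1 at 6100 nM as the only anchor. The expected step is a 1.1-fold lower number from compound 1 to compound 3 (0.04 log units; within the scatter). For compound 3 the estimated value is 5500 nM, with an expected range of 2200 nM to 14000 nM.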

Compound 3, half-maximal inhibitory concentration: 1000 nM
Estimate against measurement, compound 3: 5.5-fold (0.74 log units) above; the whole stated range lies above it.
By their numbers in this assay, from the lowest: compound 3; then compounds 2 and 1 (each within the scatter of the next).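

In this assay, going by these compounds alone, hydrogen in place of chloro on the aromatic carbon next to the ring nitrogen gives a 6.1-fold lower number from compound 1 to compound 3 (0.79 log units; beyond the scatter), the first step that isolates a single structural change. It shows that this position, para to a large group, is not indifferent to its substituent: the change from 6-chloropyridin-3-yl to pyridin-3-yl alone moves the number beyond the scatter, and the direction favours the unsubstituted ring, with the thiourea-bearing remainder of the molecule held constant. Nothing available explains the size or direction of this step, so it stands as an observation from a single pair of compounds.

As far as these compounds go, whether the lower number belongs to hydrogen specifically or whether chloro alone stands out remains open, since fluoro, methyl, methoxy or an amine at the same position would be needed to tell these readings apart. Also open, from the compounds shown here alone, is whether the same change would give a similar step on other compounds, as this single pair cannot show whether it carries over.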